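A Small Change on the Ring Nitrogen of Compound 2

This account rests on a few compounds, and the source may have more. Where it says the series, first, only, none or still open, it means among the compounds named here.

Measured so far:
compound 1 `O=C(c1cc(-c2ccc(=O)[nH]c2)on1)N1CCC(Cc2ccccc2)CC1`: 18.4%
compound 2 `O=C(Nc1ccc2[nH]c(=O)oc2c1)C(=O)N1CCN(c2ccc(C(F)(F)F)cc2)CC1`: 24.8%

In an ADME assay on the whole organism (Rattus norvegicus, strain Sprague-Dawley) for pharmacokinetics, using cassette dosing, at a dose of 1 mg/kg by the oral route (a higher number here means that a larger share of the oral dose reaches the circulation, a lower number that a smaller share of the oral dose reaches the circulation), compound 1 gives 18.4%, and compound 2 gives 24.8%. Compound 2 holds the higher of the two numbers, yet its gap to compound 1 lies within the usual scatter, so the two cannot be ranked.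

Compound 3 `O=C(Nc1ccc2[nH]c(=O)oc2c1)C(=O)N1CCN(c2ccc(Cl)c(F)c2)CC1` has not yet been measured. It differs from compound 2 by 4-chloro-3-fluorophenyl in place of 4-(trifluoromethyl)phenyl on an amine nitrogen in a ring. No change between measured compounds is available to guide the size of this step. In this assay the expected step is a number 2.8 percentage points lower from compound 2 to compound 3 (within the scatter), which stays within the scatter. Compound 3 is therefore estimated at 22%, between 8% and 40%.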

Compound 3, oral bioavailability: 28.2%
Beside the measured number, compound 3's estimate is 6.2 percentage points below it; the range from low to high includes it.
By their numbers in this assay, from the lowest: compounds 1, 2 and 3 (each within the scatter of the next).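

In this assay, putting 4-chloro-3-fluorophenyl in place of 4-(trifluoromethyl)phenyl on the amine nitrogen in the ring gives a number 3.4 percentage points higher from compound 2 to compound 3 (within the scatter). Within the data shown here, this is the first direct reading of a single change at this position, and it shows that these two substituted phenyl groups cannot be told apart by oral bioavailability. Nothing available here bears on the reason for this result.

Still open, as far as these compounds go, is whether a group of another kind on this nitrogen, such as a simple alkyl chain or a phenyl ring carrying a carboxylic acid, would produce a step beyond the scatter.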